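The compounds below may be only part of what the source reports. "The series", "measured", "known", "first", "only" and "open" are said of these compounds alone.

Compound 3 `NS(=O)(=O)c1cc(-c2nnc(CN3CCN(c4ccccc4)CC3)o2)c(Cl)cc1SCc1ccccc1` is one of three measured compounds on a shared core; in an ADME assay on microsomes from liver (Homo sapiens) for metabolic stability, read by LC-MS, using NADPH, tested at 5 uM (a lower number here means that the compound disappears faster, a higher number that the compound lasts longer), compound 3 gives 0.33 h. Compound 1 `NS(=O)(=O)c1cc(-c2nnc(CCl)o2)c(Cl)cc1SCc1ccccc1` gives 0.235 h and compound 2 `NS(=O)(=O)c1cc(-c2nnc(CN3CCC(Cc4ccccc4)CC3)o2)c(Cl)cc1SCc1ccccc1` gives 0.363 h, so compound 3 lies within the scatter of both of them. Going by the values given here, the one measured step that changes a single place, a 1.4-fold higher number from compound 1 to compound 3 (0.15 log units; within the scatter), also stays within the scatter. Compound 4 `Cc1ccc(C)c(N2CCN(Cc3nnc(-c4cc(S(N)(=O)=O)c(SCc5ccccc5)cc4Cl)o3)CC2)c1` differs from compound 3 by 2,5-dimethylphenyl in place of phenyl on an amine nitrogen in a ring. Among the compounds with values here, no measured step alters a group on that ring nitrogen, so this step has no close precedent; because even the larger exchange in a 1.4-fold higher number from compound 1 to compound 3 (0.15 log units; within the scatter) stayed within the scatter, no shift beyond the scatter is expected, a 1.1-fold higher number from compound 3 to compound 4 (0.03 log units; within the scatter). Compound 4 is therefore estimated to give 0.35 h, in a range from 0.15 h to 0.8 h.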

Compound 4, half-life: 0.208 h
Estimate against measurement, compound 4: 1.7-fold (0.23 log units) above; the range from low to high includes it.
By their numbers in this assay, from the lowest: compounds 4, 1, 3 and 2 (each within the scatter of the next).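

In this assay, going by these compounds alone, the only measured exchange on this ring nitrogen, 2,5-dimethylphenyl in place of phenyl, gives a 1.6-fold lower number from compound 3 to compound 4 (0.20 log units; within the scatter) and so stays within the usual scatter. At this position, then, adding two methyl groups to the phenyl ring does not clearly separate the two compounds. Nothing shown here explains the size of this step.

From the compounds shown here alone, it remains open whether a single methyl group on the phenyl ring would give a clearer difference. Going by these compounds, it also remains open whether an acetyl group or a carboxylic acid on that nitrogen would move the half-life beyond the scatter.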